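Removing the cyclopropyl from the aminopyrimidine urea series

A few compounds are considered here, and "the series" means these few. Any claim that something is new, unique, unknown or untested is made for them only; others in the source may bear on it.

Compound 1, `CNc1nccc(N2CC[C@H](NC(=O)Nc3ccc(Cl)c(C(F)(F)F)c3)C2)n1`, gives 10.1 nM in an assay on a protein complex for displacement of a labelled ligand from CDK8/Cyclin C (Homo sapiens), read by TR-FRET, with a stated time of 1 h; a higher number here means a weaker inhibitor, a lower number a stronger inhibitor.
Compound 2, `O=C(Nc1ccc(Cl)c(C(F)(F)F)c1)N[C@H]1CCN(c2ccc3nncn3n2)C1`, gives 4.2 nM in this assay.
Compound 3, `O=C(Nc1ccc(Cl)c(C(F)(F)F)c1)N[C@H]1CCN(c2ccnc(NC3CC3)n2)C1`, gives 20.3 nM in this assay.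

Among the three measured compounds, compound 3 carries the highest number: it sits within the scatter of compound 1 (a 2.0-fold higher number from compound 1 to compound 3 (0.30 log units; within the scatter)) but clearly apart from compound 2 (a 4.8-fold higher number from compound 2 to compound 3 (0.68 log units; beyond the scatter)), which has the lowest number of the set. Compound 2 differs from compound 1 by its bicyclic group on the ring amine (a 2.4-fold lower number from compound 1 to compound 2 (0.38 log units; beyond the scatter)).

Compound 4, `Nc1nccc(N2CC[C@H](NC(=O)Nc3ccc(Cl)c(C(F)(F)F)c3)C2)n1`, keeps the whole urea and core of compound 3 and changes only one thing: hydrogen in place of cyclopropyl on a nitrogen on an aromatic ring. Among the measured compounds shown here, the one measured step that bears on this position is the exchange of methyl for cyclopropyl on the same nitrogen, which moved the number only within the scatter (a 2.0-fold higher number from compound 1 to compound 3 (0.30 log units; within the scatter)). For the measured compounds named here, no step from methyl to hydrogen is available, so the further shrinkage to a bare amino group is extrapolated from that single, small step. Compound 4 is therefore expected to land close to compounds 1 and 3, with a step of a 1.5-fold lower number from compound 3 to compound 4 (0.16 log units; within the scatter) in this assay. Compound 4 is estimated at 14 nM, with a likely range from 5 nM to 40 nM.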

Compound 4, half-maximal inhibitory concentration in the CDK8/Cyclin C assay: 42.3 nM
For compound 4 the middle estimate is 3.0-fold (0.48 log units) below the measured one; the measured number lies above the stated range.
By their numbers in the CDK8/Cyclin C assay, from the lowest: compound 2; then compounds 1 and 3 (each within the scatter of the next); then compound 4.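

In the CDK8/Cyclin C assay compound 4 gives 42.3 nM, and hydrogen on this nitrogen separates from both alkyl groups, with a 4.2-fold higher number from compound 1 to compound 4 (0.62 log units; beyond the scatter) against methyl and a 2.1-fold higher number from compound 3 to compound 4 (0.32 log units; beyond the scatter) against cyclopropyl, even though methyl and cyclopropyl lie within the scatter of each other (a 2.0-fold higher number from compound 1 to compound 3 (0.30 log units; within the scatter)). The gap to the bicyclic group on the ring amine widens to a 10-fold higher number from compound 2 to compound 4 (1.00 log units; beyond the scatter), which leaves compound 4 the weakest inhibitor of the four in this assay. Among the compounds shown here, in a physicochemical assay for solubility, measured as kinetic solubility (on this read-out lower numbers stand for lower solubility and higher numbers for higher solubility), compound 3 gives 49200 nM and compound 4 gives 30300 nM; the same exchange of cyclopropyl for hydrogen stays within the scatter (a 1.6-fold lower number from compound 3 to compound 4 (0.21 log units; within the scatter)), so the step seen for binding has no matching step in this read-out.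

Nothing available accounts for why the bare amino group stands apart from the two alkyl-bearing compounds. From the compounds shown here alone, it remains open whether an ethyl group, a longer chain or an acetyl group on this nitrogen would sit with methyl and cyclopropyl or with hydrogen in the CDK8/Cyclin C assay, and whether any of them would reach the number of the bicyclic compound 2.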